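This account rests on a few compounds, and the source may have more. Where it says the series, first, only, none or still open, it means among the compounds named here.

Measured compounds:
- compound 1, `COc1ccc(CS(=O)(=O)/C=C/c2ccc(OC)c(OC)c2OC)cc1N`: 5900 nM
- compound 2, `COc1cc(OC)c(/C=C/S(=O)(=O)Cc2ccc(OC)c([N+](=O)[O-])c2)c(OC)c1`: "not determined" (no result reported)
- compound 3, `COc1cc(OC)c(/C=C/S(=O)(=O)Cc2ccc(OC)c(NC(C)=O)c2)c(OC)c1`: "not determined" (no result reported)

The account follows compound 2 to compound 4, `COc1ccc(CS(=O)(=O)/C=C/c2c(OC)cccc2OC)cc1[N+](=O)[O-]`. Compound 2 stands without a number: in a functional assay on T47D cells (Homo sapiens) for cytotoxicity, read by MTT assay, with a stated time of 72 h (on this read-out lower numbers stand for stronger inhibition of growth and higher numbers for weaker inhibition of growth), compound 2 is recorded only as "not determined" (no result reported), and compound 3 likewise gives "not determined" (no result reported). Among the compounds with values here, the one number in the set belongs to compound 1, which gives 5900 nM in this assay. Within the data shown here, no step between two measured compounds is available, so nothing about the effect of a change at this position can be read from the data.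

The change from compound 2 to compound 4 is hydrogen in place of methoxy on an aromatic carbon. Among the measured compounds shown here, with no measured step to lean on, the expectation for this assay is a weakening of growth inhibition that may be small and could well stay within the scatter of repeated measurements, with no firm direction claimed. On this basis, compound 4 is estimated to give 9000 nM in this assay, within a range from 1500 nM to 50000 nM.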

Compound 4, concentration for 50% growth inhibition: > 30000 nM
Compound 4: no number, only a limit; the forecaster's own chance of this, stated with the estimate: 25%; middle value at least 3.3-fold (0.52 log units) from the limit.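

In this assay compound 4 gives > 30000 nM, which is a limit and not a number. Within the data shown here, compound 2 has no number either, so no step between compound 2 and compound 4 can be read. The compounds shown leave open what hydrogen in place of methoxy does to growth inhibition.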